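A few compounds are considered here, and "the series" means these few. Any claim that something is new, unique, unknown or untested is made for them only; others in the source may bear on it.

Measured compounds:
compound 1 `C#CCN(C)CCCOc1ccc2ccc(=O)oc2c1`, 36900 nM
compound 2 `C#CCN(CCCCOc1ccc2ccc(=O)oc2c1)Cc1ccc(F)c(F)c1`, 93200 nM

In an ADME assay on isolated protein for inhibition of Amine oxidase [flavin-containing] A (Homo sapiens), read by fluorescence and Amplex Red, with stated times of 15 min and 20 min (on this read-out higher numbers stand for weaker inhibition and lower numbers for stronger inhibition), compound 1 stands at the lower of the two numbers, and compound 2 stands at the higher one, a gap beyond the usual scatter. Compound 3 `C#CCN(CCCOc1ccc2ccc(=O)oc2c1)Cc1cccc(F)c1` has not been measured. It differs from compound 1 by 3-fluorophenyl in place of hydrogen on a saturated chain carbon bound to an amine nitrogen. Because compound 2, which also carries a fluorine-bearing benzyl on the amine nitrogen, gives 93200 nM, a shift toward weaker inhibition is expected for compound 3, of moderate size, a 1.8-fold higher number from compound 1 to compound 3 (0.25 log units; within the scatter). Compound 3 is thus expected to give 65000 nM in this assay, within a range from 22000 nM to 190000 nM.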

Compound 3, half-maximal inhibitory concentration: 29300 nM
Beside the measured number, compound 3's estimate is 2.2-fold (0.35 log units) above it; low and high end bracket the measured number.
By their numbers in this assay, from the lowest: compounds 3 and 1 (each within the scatter of the next); then compound 2.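

In this assay, 3-fluorophenyl in place of hydrogen on a saturated chain carbon bound to an amine nitrogen gives a 1.3-fold lower number from compound 1 to compound 3 (0.10 log units; within the scatter). This place on the core of compound 1 therefore accepts the exchange of methyl for 3-fluorobenzyl, which adds an aromatic ring of carbon only, without a change in the number beyond the scatter. Nothing available explains this result. As far as these compounds go, what remains open is whether a plain benzyl or a cyclohexylmethyl group at this place would read the same. From the compounds shown here alone, it is also open how a longer chain would behave with the 3-fluorobenzyl group kept in place.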